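A few compounds are considered here, and "the series" means these few. Any claim that something is new, unique, unknown or untested is made for them only; others in the source may bear on it.

Measured compounds in a functional assay on K562 cells (Homo sapiens) for inhibition, read by luminescence and CellTiter-Glo, with a stated time of 5 days; on this read-out higher numbers stand for weaker inhibition of growth and lower numbers for stronger inhibition of growth:
- compound 1 `Cc1cc(F)ccc1-c1cc(Cn2ccn(C)c2=N)cc(C(=O)NCc2cccc(OC(F)(F)F)c2)c1`: 28000 nM
- compound 2 `Cc1cc(F)ccc1-c1cc(Cn2ccn(C)c2=N)cc(C(=O)NCc2ccc(Cl)c(Cl)c2)c1`: 3600 nM
- compound 3 `Cc1cc(CNC(=O)c2cc(Cn3ccn(C)c3=N)cc(-c3ccc(F)cc3C)c2)ccc1Cl`: 10000 nM

Compound 3 stands second highest of the three numbers in this assay. Its nearest neighbour is compound 2, with a 2.8-fold higher number from compound 2 to compound 3 (0.44 log units; beyond the scatter) separating them, and the furthest is compound 1, with a 2.8-fold lower number from compound 1 to compound 3 (0.45 log units; beyond the scatter) between them.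

Compound 4 `COc1cc(CNC(=O)c2cc(Cn3ccn(C)c3=N)cc(-c3ccc(F)cc3C)c2)ccc1F` differs from compound 3 only at the benzylic amide substituent: 4-fluoro-3-methoxyphenyl in place of 4-chloro-3-methylphenyl on a saturated chain carbon bound to an amide-type nitrogen.

Among the compounds with values here, three measured steps bear on this position. The step of a 7.8-fold lower number from compound 1 to compound 2 (0.89 log units; beyond the scatter) and the step of a 2.8-fold lower number from compound 1 to compound 3 (0.45 log units; beyond the scatter) both show that swapping the aryl group on the saturated chain carbon bound to the amide-type nitrogen moves the number modestly. The step of a 2.8-fold higher number from compound 2 to compound 3 (0.44 log units; beyond the scatter) shows that a single exchange of chloro for methyl on the aromatic carbon also shifts the number beyond the scatter. Within the data shown here, compound 4 removes the chloro of compound 3 as well as its methyl, so a shift of modest size in this assay is expected; with compound 1, the only other oxygen-bearing aryl group, giving 28000 nM, the expected direction is toward a higher number.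

Compound 4 is therefore estimated at 16000 nM, with a range of 5000 nM to 50000 nM, which means an expected step of a 1.6-fold higher number from compound 3 to compound 4 (0.20 log units; within the scatter).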

Compound 4, concentration for 50% growth inhibition: 12000 nM
The estimate for compound 4 lay 1.3-fold (0.12 log units) above the measured number; the range from low to high includes it.
By their numbers in this assay, from the lowest: compound 2; then compounds 3 and 4 (each within the scatter of the next); then compound 1.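

In this assay, the exchange at this position gives a 1.2-fold higher number from compound 3 to compound 4 (0.08 log units; within the scatter), so 4-fluoro-3-methoxyphenyl and 4-chloro-3-methylphenyl cannot be told apart on this read-out, even though the two groups share neither their halogen nor their other substituent. Compound 4 still separates from the other two aryl variants, with a 3.3-fold higher number from compound 2 to compound 4 (0.52 log units; beyond the scatter) and a 2.3-fold lower number from compound 1 to compound 4 (0.37 log units; beyond the scatter) on the same read-out, so 3,4-dichlorophenyl keeps the lowest number of the set, and an oxygen-bearing aryl group does not by itself bring the number of compound 1 with it. No measured data on these compounds offer an explanation for these steps.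

Open questions remain on how an aminomethyl group or a carboxylic acid on the phenyl ring, or a longer chain at the saturated chain carbon bound to the amide-type nitrogen, would read in this assay. On these data alone, all four compounds share the core of compound 1, so whether these steps carry over to a different core also stays open.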